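Cyclopropyl in place of 4-methylphenyl on the amide-type nitrogen

The source may hold more compounds than are shown below. What is called first, only, known or untested is meant among the compounds shown, and "the series" means these compounds.

In a functional assay on A549 cells (Homo sapiens) for antiproliferative activity, read by MTT assay, with a stated time of 72 h (a higher number here means a weaker inhibitor, a lower number a stronger inhibitor), compound 1 (`COc1ccc(N2C(=O)COc3ccc(-c4cnc(Cl)c(NS(=O)(=O)c5ccc(F)cc5)c4)cc32)cc1`) gives 30400 nM and compound 2 (`Cc1ccc(N2C(=O)COc3ccc(-c4cnc(Cl)c(NS(=O)(=O)c5ccc(F)cc5)c4)cc32)cc1`) gives 30900 nM. These two values lie within the scatter of each other, so compound 2 stands level with compound 1.

Compound 3 (`O=C1COc2ccc(-c3cnc(Cl)c(NS(=O)(=O)c4ccc(F)cc4)c3)cc2N1C1CC1`) carries cyclopropyl in place of 4-methylphenyl on an amide-type nitrogen in a ring.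

For the measured compounds named here, the only measured step, a 1.0-fold higher number from compound 1 to compound 2 (0.01 log units; within the scatter), is methyl in place of methoxy on an aromatic carbon and stays within the scatter. Going by the values given here, it changes a group on the aromatic ring but does not remove that ring, so no measured step tests the present change directly. On this limited evidence, no step beyond the scatter is expected in either direction, and the expected step is a 1.2-fold lower number from compound 2 to compound 3 (0.09 log units; within the scatter). The estimate for compound 3 is 25000 nM, with an expected range of 8000 nM to 70000 nM.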

Compound 3, half-maximal inhibitory concentration: 4330 nM
Estimate against measurement, compound 3: 5.8-fold (0.76 log units) above; the measured number lies below the stated range.
By their numbers in this assay, from the lowest: compound 3; then compounds 1 and 2 (each within the scatter of the next).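

In this assay, for the compounds shown here, the amide-type nitrogen in a ring is the first place where a change moves the number beyond the scatter: cyclopropyl in place of 4-methylphenyl gives a 7.1-fold lower number from compound 2 to compound 3 (0.85 log units; beyond the scatter), and cyclopropyl in place of 4-methoxyphenyl gives a 7.0-fold lower number from compound 1 to compound 3 (0.85 log units; beyond the scatter). The two steps print almost alike, so an aromatic ring on this nitrogen is not needed for activity in this assay, and among the three compounds the lowest number goes with the group of 3 heavy atoms. Nothing measured here bears on the cause of these steps.

Going by these compounds alone, only one non-aromatic group stands at this nitrogen, so the loss of the aromatic ring and the drop in heavy atoms cannot be told apart. Cyclohexyl, a plain ethyl chain or an aminoethyl chain at this nitrogen remain open.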